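The source may report more compounds than this note shows. Statements on the series, on what has been measured and on what is new or still open speak of the compounds shown alone.

In a functional assay on the whole organism (artery, strain albino) with Rattus norvegicus as the target, with a stated time of 300 min, at a dose of 10 mg/kg by the oral route (a lower number here means less inhibition, a higher number more inhibition at the dose given (going by the name of the read-out)), compound 1 `COc1ccc(C2N=C(SCc3ccc(Cl)cc3)NC(C)=C2C(=O)Nc2ccc(Br)cc2)cc1` gives 37.9%. Compound 2 `COc1ccc(C2N=C(SCc3ccc(F)cc3)NC(C)=C2C(=O)Nc2ccc(Br)cc2)cc1` differs from it by fluoro in place of chloro on an aromatic carbon and gives 26.2%, a step of a number 11.7 percentage points lower from compound 1 to compound 2 (beyond the scatter). Compound 3 `CC1=C(C(=O)Nc2ccc([N+](=O)[O-])cc2)C(c2cccc([N+](=O)[O-])c2)N=C(SCc2ccc(Cl)cc2)N1` has a core built on a different pattern from that of compound 1, a difference that is not broken down here; in this assay compound 3 gives 24.1%. Against compound 1 that value stands beyond the scatter lower, while against compound 2 the two values lie within the scatter of each other. Compound 4 `CC1=C(C(=O)Nc2ccc([N+](=O)[O-])cc2)C(c2cccc([N+](=O)[O-])c2)N=C(SCc2ccc(F)cc2)N1` has not yet been measured. It differs from compound 3 by fluoro in place of chloro on an aromatic carbon, the same change, at the same kind of place, as that from compound 1 to compound 2. A step of a number 9.1 percentage points lower from compound 3 to compound 4 (within the scatter) is expected from compound 3 to compound 4, resting on the measured step of a number 11.7 percentage points lower from compound 1 to compound 2 (beyond the scatter). Compound 4 is therefore estimated at 15%, expected to fall between 3% and 28%.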

Compound 4, a percentage reported as inhibition, in the whole organism at one dose (the size of the read-out at that dose, not a potency): 27.2%
For compound 4 the middle estimate is 12.2 percentage points below the measured one; low and high end bracket the measured number.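

On the second core, the change from 4-chlorobenzyl to 4-fluorobenzyl gives a number 3.1 percentage points higher from compound 3 to compound 4 (within the scatter) in this assay. The change therefore does not act alike on the two cores: the same change on two cores in this assay, a number 11.7 percentage points lower (beyond the scatter) from compound 1 to compound 2 and a number 3.1 percentage points higher (within the scatter) from compound 3 to compound 4, 14.8 percentage points apart, beyond the scatter of two such steps The step seen on the core of compound 1 thus cannot be carried over to the other core in this series, but two pairs do not show which of the several differences between the cores sets the steps apart.

The compounds shown leave open how an unsubstituted benzyl group or a longer alkyl chain would compare in place of these halogenated benzyl groups. They also leave open what an amine would give in place of the nitro groups.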